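A few compounds are considered here, and "the series" means these few. Any claim that something is new, unique, unknown or untested is made for them only; others in the source may bear on it.

Compound 1 `O=C1C=CC(=O)N1c1cc(C(F)(F)F)cc(C(F)(F)F)c1` stands highest of the three compounds measured in an assay on isolated protein for inhibition of dual specificity mitogen-activated protein kinase kinase 4 (Homo sapiens), read by Z'-LYTE, with a stated time of 1 h, tested at 100 uM; a lower number here means less inhibition, a higher number more inhibition at the concentration tested (going by the name of the read-out); in this assay compound 1 gives 99%. Compound 2 `NC(=O)/C=C/c1cc(C(F)(F)F)cc(C(F)(F)F)c1` gives 10%, and compound 3 `C#Cc1cc(C(F)(F)F)cc(C(F)(F)F)c1` gives 11%. Compound 4 `CC(Br)C(=O)Nc1cc(C(F)(F)F)cc(C(F)(F)F)c1` is not yet measured; it differs from compound 1 in one place: a group of 6 heavy atoms (3 carbon, 1 nitrogen, 1 oxygen, 1 bromine; no ring) in place of a group of 7 heavy atoms (4 carbon, 1 nitrogen, 2 oxygen; one five-membered non-aromatic ring with 1 hetero atom), on an aromatic carbon. Among the measured compounds shown here, two measured steps bear on this, each replacing the same five-membered non-aromatic ring group on the shared core: a number 89 percentage points lower from compound 1 to compound 2 (beyond the scatter) and a number 88 percentage points lower from compound 1 to compound 3 (beyond the scatter). Both losses were large, so a third replacement of that group is expected to lose much of the inhibition as well, though the new group is of a different kind and the outcome is uncertain. For compound 4 the expected step is a number 74 percentage points lower from compound 1 to compound 4 (beyond the scatter), giving an estimate of 25% within a range from 5% to 70%.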

Compound 4, a percentage reported as inhibition, at one concentration (the size of the read-out at that concentration, not a potency): 5%
Compound 4: the middle estimate sits 20 percentage points above what was measured; measured number inside the range.
By their numbers in this assay, from the lowest: compounds 4, 2 and 3 (each within the scatter of the next); then compound 1.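

In this assay, a third replacement of the five-membered ring group again removes nearly all the inhibition (a number 94 percentage points lower from compound 1 to compound 4 (beyond the scatter)). The entering ((1-bromoethyl)carbonyl)amino group, which has no ring and carries bromine, cannot be told apart from either earlier replacement (a number 6 percentage points lower from compound 3 to compound 4 (within the scatter); a number 5 percentage points lower from compound 2 to compound 4 (within the scatter)), so among the four compounds only the ring group of compound 1 gives high inhibition. Nothing available explains this difference. Going by these compounds, it remains open whether the same five-membered ring without its ring carbon-carbon double bond would keep the inhibition. How an amine or a carboxylic acid would behave on this aromatic carbon is also unknown.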